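Cyclopropyl for tert-butoxy on a rearranged bicyclic core

This account rests on a few compounds, and the source may have more. Where it says the series, first, only, none or still open, it means among the compounds named here.

Three compounds share an amide to the chlorophenyl-tetrazole fragment and a hydroxy-acyl group on a bicyclic amine, and were tested in a functional assay on a cell-free system (plasma, Homo sapiens), with a stated time of 3 min; on this read-out higher numbers stand for weaker inhibition and lower numbers for stronger inhibition. Compound 1 `O=C(NCc1cc(Cl)ccc1-n1cnnn1)[C@@H]1C[C@@H]2C[C@@H]2N1C(=O)[C@H](O)CC1CC1` gives 1700 nM in this assay. Compound 2 `CC(C)(C)OC[C@@H](O)C(=O)N1[C@H](C(=O)NCc2cc(Cl)ccc2-n2cnnn2)C[C@@H]2C[C@@H]21` gives 500 nM in this assay. Compound 3 `CC(C)(C)OC[C@@H](O)C(=O)N1C[C@@H]2C[C@@H]2[C@H]1C(=O)NCc1cc(Cl)ccc1-n1cnnn1` gives 570 nM in this assay. Compounds 2 and 3 are built from the same atoms joined differently; the difference between the two cores is not broken down here, and their two numbers lie within the scatter of each other.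

Between the measured pair, the change cyclopropyl in place of tert-butoxy on a saturated chain carbon, two bonds along the chain from a carbonyl carbon and an oxygen on a saturated carbon produced a 3.4-fold higher number from compound 2 to compound 1 (0.53 log units; beyond the scatter). Compound 4 `O=C(NCc1cc(Cl)ccc1-n1cnnn1)[C@@H]1[C@H]2C[C@H]2CN1C(=O)[C@H](O)CC1CC1` has not yet been measured. It relates to compound 3 by the change (cyclopropyl in place of tert-butoxy on a saturated chain carbon, two bonds along the chain from a carbonyl carbon and an oxygen on a saturated carbon), the same change as that from compound 2 to compound 1, at a place described in the same words.

Because the change from compound 2 to compound 1 gave a 3.4-fold higher number from compound 2 to compound 1 (0.53 log units; beyond the scatter), and because compound 3 starts from 570 nM, compound 4 is expected to show a step of about a 3.3-fold higher number from compound 3 to compound 4 (0.52 log units; beyond the scatter) in this assay. On that basis compound 4 is estimated at 1900 nM in this assay, most likely between 900 nM and 4000 nM, an expectation that rests on a single measured instance of the change and on cores whose difference is not broken down.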

Compound 4, half-maximal inhibitory concentration: 1400 nM
The estimate for compound 4 lay 1.4-fold (0.13 log units) above the measured number; the range from low to high includes it.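

In this assay, putting cyclopropyl in place of tert-butoxy on the core of compound 3 gave a 2.5-fold higher number from compound 3 to compound 4 (0.39 log units; beyond the scatter), a step in the same direction as the one seen on the other core. Set side by side, the two steps agree in size: the same change on two cores in this assay, a 3.4-fold higher number (0.53 log units; beyond the scatter) from compound 2 to compound 1 and a 2.5-fold higher number (0.39 log units; beyond the scatter) from compound 3 to compound 4, 1.4-fold (0.14 log units) apart, within the scatter of two such steps. On these two cores and in this one read-out, the change therefore carried over in both direction and size, but that rests on two pairs that share the same chlorophenyl-tetrazole amide, so it shows nothing about other cores or other amide fragments, and it does not show which part of the change matters, as tert-butoxy brings an oxygen and no ring whereas cyclopropyl brings a ring and no oxygen.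

The compounds shown leave open whether the oxygen, the ring or the size of the group goes with the step, a question that a plain tert-butyl, an isopropoxy group or a longer carbon chain in the same place could help to separate. They also leave open whether an amine or a carboxylic acid at that position would follow the same course on both cores.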